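Benzylamide in place of anilide: expectation for compound 3

This account rests on a few compounds, and the source may have more. Where it says the series, first, only, none or still open, it means among the compounds named here.

Compound 1 `COc1ccc2nc(C)cc(OCC(=O)Nc3cc(C)cc(C)c3)c2c1` is the anchor of this small set. Among the measured compounds shown here, in a toxicity assay on HepG2 cells (Homo sapiens) for inhibition, read by CellTiter-Glo, with a stated time of 48 h (a lower number here means a stronger inhibitor, a higher number a weaker inhibitor), compound 1 gives 20000 nM, the only numerical value among the two measured compounds. Compound 2 `CSc1ccc2nc(C)cc(OCC(=O)Nc3cc(C)cc(C)c3)c2c1` differs from it by methylsulfanyl in place of methoxy on an aromatic carbon. In this assay compound 2 returns > 100000 nM, which is a limit of the assay rather than a number. For the measured compounds named here, the single measured step, an at least 5.0-fold higher number from compound 1 to compound 2 (0.69 log units; beyond the scatter), thus rests on the limit of > 100000 nM in this assay, at which 1 of the 2 values shown sits, and concerns the aromatic methoxy alone.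

Compound 3 `COc1ccc2nc(C)cc(OCC(=O)NCc3cc(C)cc(C)c3)c2c1` carries a different change: 3,5-dimethylbenzyl in place of 3,5-dimethylphenyl on an amide-type nitrogen. Going by the values given here, no measured step touches this amide-type nitrogen, so the step from compound 1 to compound 3 has no direct precedent here, and the record gives no direction for it. The expectation for compound 3 therefore leans on compound 1 only, with wide uncertainty and a real chance that only a limit is reported. Compound 3 is expected at 30000 nM, in a range from 8000 nM to 100000 nM. This amounts to an expected step of a 1.5-fold higher number from compound 1 to compound 3 (0.18 log units; within the scatter), not clearly beyond the scatter in either direction.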

Compound 3, half-maximal inhibitory concentration: > 100000 nM
Compound 3 gave a limit, no number (the forecaster's own chance of this, stated with the estimate: 35%); at least 3.3-fold (0.52 log units) between middle value and limit.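

In this assay the amide-type nitrogen now carries a measured step, an at least 5.0-fold higher number from compound 1 to compound 3 (0.69 log units; beyond the scatter) for 3,5-dimethylbenzyl in place of 3,5-dimethylphenyl, so this position does respond to a change that earlier steps left untouched. As far as these compounds go, the value of compound 3 is a limit of the assay and not a number, so the step gives a direction and a smallest size, while its full size stays unknown. Compound 1 is now the only compound shown with a numerical value, and each of the two single changes made to it, one on the aromatic methoxy and one on the amide-type nitrogen, ends at the same limit: the limit of > 100000 nM in this assay, at which 2 of the 3 values shown sit.

From the compounds shown here alone, it remains open whether a longer chain on the amide-type nitrogen, such as 2-phenylethyl, or a methyl group in place of the amide hydrogen of compound 1 would give a number at all in this assay. Equally open, going by these compounds, is whether an amine or a carboxylic acid on the 3,5-dimethylphenyl of compound 1 would move the number in either direction.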